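The source may report more compounds than this note shows. Statements on the series, on what has been measured and on what is new or still open speak of the compounds shown alone.

Three compounds share a common core and are compared in an in vitro assay on LLC-PK1 cells for displacement of a labelled ligand from growth hormone secretagogue receptor type 1 (Homo sapiens) (a higher number here means a weaker inhibitor, a lower number a stronger inhibitor), where they span a wide range. Compound 1 `COc1ccc(Cn2c(CCc3ccccc3)nnc2[C@H](NC(=O)C(C)(C)N)c2c[nH]c3ccccc23)c(OC)c1` gives 60 nM. Compound 2 `COc1ccc(Cn2c(CCc3ccccc3)nnc2[C@H](NC(=O)c2ccccn2)c2c[nH]c3ccccc23)c(OC)c1` gives 1.1 nM, the lowest of the three numbers, with steps to both others that lie beyond the scatter. Compound 3 `CCc1ccc(-n2c(CCc3c[nH]c4ccccc34)nnc2[C@H](NC(=O)c2ccccn2)c2c[nH]c3ccccc23)cc1` differs from compound 2 in several places at once; in this assay compound 3 gives 49 nM. Among the compounds with values here, the only step between compounds that differ in a single place is a 55-fold lower number from compound 1 to compound 2 (1.74 log units; beyond the scatter), an exchange of the group on the carbonyl carbon.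

Compound 4 `COc1ccc(Cn2c(CCc3ccccc3)nnc2[C@H](NC(=O)c2ccccn2)c2c[nH]c3ccccc23)cc1` has not yet been measured. It differs from compound 2 by hydrogen in place of methoxy on an aromatic carbon; read one bond further out, a 2,4-dimethoxybenzyl group becomes a 4-methoxybenzyl group. Within the data shown here, no measured step touches this part of the molecule: the step from compound 1 to compound 2 concerns the carbonyl substituent, and compound 3 differs from compound 2 in too many places for its value to isolate the methoxy. The expectation therefore rests only on the modesty of the change, the loss of a methoxy from the benzyl group while everything else stays. Such a removal is expected to move this assay little, at most a slight rise, giving a 2.3-fold higher number from compound 2 to compound 4 (0.36 log units; beyond the scatter). Compound 4 is thus estimated at 2.5 nM, with a range from 0.8 nM to 8 nM.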

Compound 4, half-maximal inhibitory concentration: 0.7 nM
For compound 4 the middle estimate is 3.6-fold (0.55 log units) above the measured one, and the stated range ends above it.
By their numbers in this assay, from the lowest: compounds 4 and 2 (each within the scatter of the next); then compounds 3 and 1 (each within the scatter of the next).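

In this assay, within the data shown here, the exchange gives a 1.6-fold lower number from compound 2 to compound 4 (0.20 log units; within the scatter), the first reading at this position, which the step on the carbonyl carbon and the several differences of compound 3 could not provide. With the pyridin-2-yl amide and the rest of the molecule held constant, the methoxy ortho to a large group can therefore give way to hydrogen, turning 2,4-dimethoxybenzyl into 4-methoxybenzyl, without a step beyond the scatter. Nothing shown explains why this exchange leaves the number within the scatter.

The compounds shown leave open whether the same exchange would behave alike with the 1-amino-1-methylethyl group of compound 1 on the carbonyl carbon, and what happens when the methoxy that remains in compound 4 is removed or replaced. They also leave open how this position would respond to something other than methoxy or hydrogen, such as a fluorine atom, a hydroxyl, an amine, a carboxylic acid or a longer chain such as ethoxy.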